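Removing one hydroxy group from an inactive compound

The compounds below may be only part of what the source reports. "The series", "measured", "known", "first", "only" and "open" are said of these compounds alone.

Measured in an ADME assay on MIA PaCa-2 cells (Homo sapiens) for cytotoxicity, read by MTT assay, with a stated time of 72 h; on this read-out higher numbers stand for weaker inhibition and lower numbers for stronger inhibition:
Compound 1 `C=CCOc1cc(C2=C(c3cc(OC)c(OC)c(OC)c3)C(=O)C(O)C2)ccc1OC`: > 100 ug/mL (a limit)
Compound 2 `COc1ccc(C2=C(c3cc(OC)c(OC)c(OC)c3)C(=O)CC2O)cc1O`: > 100 ug/mL (a limit)

Compound 2 gives > 100 ug/mL, which is a limit of the assay and not a number. Compound 1 gives > 100 ug/mL, which is also only a limit. What the two compounds share is the limit of > 100 ug/mL in this assay, at which 2 of the 2 values shown sit. Among the compounds with values here, neither has a true number yet, so no step between them can be read.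

Compound 3 `COc1ccc(C2=C(c3cc(OC)c(OC)c(OC)c3)C(=O)CC2O)cc1` differs from compound 2 in one place, with hydrogen in place of hydroxy on an aromatic carbon, so that 3-hydroxy-4-methoxyphenyl becomes 4-methoxyphenyl (hydrogen in place of hydroxy on an aromatic carbon). The hydroxy group that leaves sits ortho to a methoxy group and meta to a large group.

Within the data shown here, no measured step shows what this change does in this assay. The expectation rests on compound 2 and its limit of > 100 ug/mL. The expected change, a number no higher from compound 2 to compound 3 (the limit leaves the size open), is none beyond the usual scatter, in either direction. Compound 3 is estimated at 100 ug/mL, with an expected range from 30 ug/mL to 300 ug/mL, and the result may well be a limit again.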

Compound 3, half-maximal inhibitory concentration: > 100 ug/mL
Compound 3 gave a limit, no number; the forecaster's own chance of this, stated with the estimate: 65%; the middle value lies on the limit itself.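

In this assay, within the data shown here, compound 3 gives > 100 ug/mL, which is a limit and not a number, so no step from compound 2 to compound 3 can be read. The compounds shown leave open what true number each one has, and whether hydrogen in place of hydroxy changes anything, as all of them share one result: the limit of > 100 ug/mL in this assay, at which 3 of the 3 values shown sit.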